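This account rests on a few compounds, and the source may have more. Where it says the series, first, only, none or still open, it means among the compounds named here.

Compound 3 `CC1=C(C(=O)OC(C)C)C(c2ccco2)N/C(=N/C#N)N1` carries a furan-2-yl group on a saturated ring carbon of the shared core. Within the data shown here, in an assay on cells for displacement of a labelled ligand from adenosine receptor A1 (Homo sapiens), with a stated time of 60 min, tested at 1 uM (a lower number here means less inhibition, a higher number more inhibition at the concentration tested (going by the name of the read-out)), compound 3 gives 21%, the highest of the three numbers so far, though compound 2 sits within the scatter of it. Compound 2 `CC1=C(C(=O)OC(C)C)C(c2ccsc2)N/C(=N/C#N)N1`, with thiophen-3-yl at the same carbon, gives 11% in this assay; the step of a number 10 percentage points higher from compound 2 to compound 3 (within the scatter) stays within the scatter. Compound 1 `CC1=C(C(=O)OC(C)C)[C@@H](c2ccco2)N/C(=N/C#N)N1` gives 2% in this assay; the step of a number 19 percentage points higher from compound 1 to compound 3 (beyond the scatter) is the only one beyond the scatter, and it goes with the fact that one of compounds 1 and 3 is drawn with a defined configuration and the other without, at the place where they differ rather than with any change of atoms or bonds.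

Compound 4 `CC1=C(C(=O)OC(C)C)C(c2ccoc2)N/C(=N/C#N)N1` differs from compound 3 by furan-3-yl in place of furan-2-yl on a saturated ring carbon. Among the measured compounds shown here, the one measured step that bears on it is the exchange of one five-membered heteroaryl for another at that carbon, a number 10 percentage points higher from compound 2 to compound 3 (within the scatter). For the measured compounds named here, a further swap of the same kind is therefore not expected to shift this assay beyond the scatter in either direction, and all three numbers so far lie low. Compound 4 is expected to give 15% in this assay, between 3% and 32%. The expected step is a number 6 percentage points lower from compound 3 to compound 4 (within the scatter).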

Compound 4, a percentage reported as inhibition, at one concentration (the size of the read-out at that concentration, not a potency): 34%
Compound 4: middle estimate off by 19 percentage points, on the low side, outside the stated range (above it).
By their numbers in this assay, from the lowest: compounds 1, 2 and 3 (each within the scatter of the next, the first and the last beyond it); then compound 4.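

With the atoms unchanged and only the point of attachment moved, furan-3-yl in place of furan-2-yl on this saturated ring carbon gives a number 13 percentage points higher from compound 3 to compound 4 (beyond the scatter) in this assay, so this position responds to how the furan is joined, which the earlier heteroaryl exchange, a number 10 percentage points higher from compound 2 to compound 3 (within the scatter), did not show. With attachment at the 3-position kept, furan-3-yl in place of thiophen-3-yl gives a number 23 percentage points higher from compound 2 to compound 4 (beyond the scatter), so the identity of the heteroaryl also counts once the two are compared at the same attachment. Nothing in the data shown accounts for either step.

On these data alone, compound 4 is drawn without a configuration at this carbon, so the contribution of each separate stereoisomer remains open. Also open, as far as these compounds go, is whether a phenyl or a cyclohexyl group at this carbon would give a higher or lower number than the furan-3-yl group.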